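Replacing the piperidine arm: an expected outcome for compound 3

This account rests on a few compounds, and the source may have more. Where it says the series, first, only, none or still open, it means among the compounds named here.

In a functional assay on CCRF-CEM cells for antagonist activity at C-X-C chemokine receptor type 4 (Homo sapiens), read by calcium flux, with stated times of 25 min and 90 s (on this read-out higher numbers stand for weaker inhibition and lower numbers for stronger inhibition), compound 1 `c1ccc2c(c1)CN[C@@H](CN(CC[C@@H]1CCCNC1)[C@H]1CCCc3cccnc31)C2` gives 161 nM. Within the data shown here, compound 2 `c1cnc2c(c1)CN[C@@H](CN(CCCN1CCNCC1)[C@H]1CCCc3cccnc31)C2` gives 171 nM in this assay, a number within the usual scatter of that for compound 1, so the two are not ordered against each other; compound 1 simply holds the lower of the two numbers measured so far, and nothing in that pair can be called a trend.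

The step from compound 1 leads to compound 3 `c1ccc2c(c1)CN[C@@H](CN(CCCN1CCN(C3CC3)CC1)[C@H]1CCCc3cccnc31)C2`, which has not yet been measured in this assay. The change is (4-cyclopropylpiperazin-1-yl)methyl in place of piperidin-3-yl on a saturated chain carbon, two bonds along the chain from an amine nitrogen. Among the measured compounds shown here, no measured pair in this set differs in a single place, so no measured step offers a direct yardstick for what this swap does. What the two measured compounds show is that a larger basic side arm, as in compound 2, sits at about the same potency as the piperidine arm of compound 1.

On that basis compound 3 is expected to give about 250 nM in this assay, somewhere between 80 nM and 800 nM, which would mean an estimated step of a 1.6-fold higher number from compound 1 to compound 3 (0.19 log units; within the scatter) that is small and, if anything, toward slightly weaker inhibition.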

Compound 3, half-maximal inhibitory concentration: 50 nM
For compound 3 the middle estimate is 5.0-fold (0.70 log units) above the measured one, and the stated range ends above it.
By their numbers in this assay, from the lowest: compound 3; then compounds 1 and 2 (each within the scatter of the next).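

Among these compounds, this position, on a saturated chain carbon, two bonds along the chain from an amine nitrogen, does more than accept a larger arm: (4-cyclopropylpiperazin-1-yl)methyl in place of piperidin-3-yl gives a 3.2-fold lower number from compound 1 to compound 3 (0.51 log units; beyond the scatter) in this assay, a modest step beyond the scatter and the first single-place comparison in the set. It also shows that the hydrogen-bond donor and the defined stereocentre counted on piperidin-3-yl are not needed for inhibition at this level, as the entering arm has neither and still gives the lower number. No measurement shown here bears on why the step occurs.

The swap changes the whole arm at once, leaving open how much of the step belongs to the cyclopropyl ring, how much to the six-membered ring with its two nitrogens, and how much to the added chain carbon. An arm ending in a methyl or isopropyl group in place of cyclopropyl, or a piperazine carried on a longer chain, would be needed to tell these parts apart.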